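From Methylcarbamoyl to Hydroxymethyl on a Shared Core

A few compounds are considered here, and "the series" means these few. Any claim that something is new, unique, unknown or untested is made for them only; others in the source may bear on it.

Compound 3, `CNC(=O)c1cc(N)c(Nc2ccc(C#N)cc2)cc1Oc1c(C)cc(CCC#N)cc1C`, was tested in an ADME assay on TZM cells (Homo sapiens) for cytotoxicity, read by XTT assay, with a stated time of 4 days; a lower number here means that less compound is tolerated, a higher number that more compound is tolerated. In this assay compound 3 gives > 9100 nM, which is a limit of the assay and not a number. Its close relative compound 2, `Cc1cc(CCC#N)cc(C)c1Oc1cc(Nc2ccc(C#N)cc2)c(N)cc1N`, differs from it by methylcarbamoyl in place of amino on an aromatic carbon. In this assay compound 2 gives > 25000 nM, again a limit rather than a number. The step that the two limits leave unreadable from compound 2 to compound 3 cannot be read because the limit of > 25000 nM in this assay, at which 1 of the 3 values shown sits, and the limit of > 9100 nM in this assay, at which 1 of the 3 values shown sits, form its two ends. Compound 1, `Cc1cc(/C=C/C#N)cc(C)c1Oc1cc(Nc2ccc(C#N)cc2)c(N)cc1CO`, also carries a hydroxymethyl group. In this assay, within the data shown here, compound 1 gives 16300 nM, the one plain number among the three.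

Compound 4, `Cc1cc(CCC#N)cc(C)c1Oc1cc(Nc2ccc(C#N)cc2)c(N)cc1CO`, is reached from compound 3 by hydroxymethyl in place of methylcarbamoyl on an aromatic carbon. Among the measured compounds shown here, no measured step in this set tracks that exact change, so the expectation leans on compound 1, whose 16300 nM shows where a hydroxymethyl-bearing member of this series has landed. For compound 4 a step that the limit leaves unreadable from compound 3 to compound 4 is expected, which would leave it close to the region where this assay may again report only a limit. The estimate for compound 4 is 20000 nM, with a range from 8000 nM to 50000 nM.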

Compound 4, half-maximal cytotoxic concentration in the TZM assay: > 23800 nM
Compound 4 ended at the assay's limit; the forecaster's own chance of this, stated with the estimate: 50%; middle value at least 1.1-fold (0.07 log units) from the limit.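

Among these compounds, in the TZM assay the one step that can be read is an at least 1.4-fold higher number from compound 1 to compound 4 (0.16 log units; that floor lies within the scatter), which comes with 2-cyanoethyl in place of 2-cyanoethenyl, and it gives only a floor for the size of that change, not a measured size. The value of compound 4 in the TZM assay is a limit and not a number, so the steps that join it to compound 2 and compound 3 cannot be read, and the same holds for hydroxymethyl in place of methylcarbamoyl at this position: the limit of > 23800 nM in the TZM assay, at which 1 of the 4 values shown sits. In a physicochemical assay for solubility, with a stated time of 4 h, at pH 2.0 (a lower number here means a less soluble compound, a higher number a more soluble compound), compound 3 gives 44.7 ug/mL and compound 4 gives 89.8 ug/mL, so the same change gives a 2.0-fold higher number from compound 3 to compound 4 (0.30 log units; within the scatter), and this second assay shows no clear separation between the two groups.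

On these data alone, how far hydroxymethyl in place of methylcarbamoyl moves the tolerated concentration in the TZM assay stays open, with a limit at both ends of that change. The compounds shown also leave open how a carboxylic acid or a 2-hydroxyethyl group at this position on the shared core would fare in the TZM assay and the physicochemical assay.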